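The source may hold more compounds than are shown below. What is called first, only, known or untested is meant among the compounds shown, and "the series" means these compounds.

Measured so far in a functional assay, read by spectrophotometry, with a stated time of 30 min; on this read-out lower numbers stand for stronger inhibition and higher numbers for weaker inhibition:
- compound 1, `Cc1ccc2[nH]c(=O)c(/C=N/c3ccccc3O)cc2c1`: in this assay compound 1 gives 26200 nM
- compound 2, `Cc1ccc2[nH]c(=O)c(/C=N/Nc3ccc([N+](=O)[O-])cc3[N+](=O)[O-])cc2c1`: in this assay compound 2 gives "not active" (no number reported)
- compound 3, `O=c1[nH]c2ccccc2cc1/C=N/c1ccccc1O`: in this assay compound 3 gives 22800 nM

Not yet measured: compound 4, `O=c1[nH]c2ccccc2cc1/C=N/Nc1ccc([N+](=O)[O-])cc1[N+](=O)[O-]`.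

The pair compound 1 and compound 3 differs by hydrogen in place of methyl on an aromatic carbon. The step here is a 1.1-fold lower number from compound 1 to compound 3 (0.06 log units; within the scatter), so in this assay the change left the read-out essentially unmoved.

Compound 4 relates to compound 2 by the same change, (hydrogen in place of methyl on an aromatic carbon); the two "place" descriptions are identical word for word. How the core of compound 2 differs from the core of compound 1 is not broken down here. Compound 2 returned no number in this assay at all.

Expectation for compound 4: because the matched pair gave a 1.1-fold lower number from compound 1 to compound 3 (0.06 log units; within the scatter), the change is expected to carry little weight, and compound 4 is expected to come out much like compound 2, most probably again without a number. Should a number be reported, compound 4 is estimated at 60000 nM, expected to lie between 20000 nM and 250000 nM.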

Compound 4, half-maximal inhibitory concentration: 190000 nM
Beside the measured number, compound 4's estimate is 3.2-fold (0.50 log units) below it, and the stated range covers the measured number.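

With no number for compound 2 in this assay, no step can be read from it to compound 4, which gives 190000 nM. The compounds shown leave open whether hydrogen in place of methyl matters more alongside the side chain of compound 2 than alongside that of compound 1. No supporting evidence bears on this result.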